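Swapping the amine on the thiocarbonyl carbon

The source may hold more compounds than are shown below. What is called first, only, known or untested is meant among the compounds shown, and "the series" means these compounds.

Of the compounds shown here, three have so far been tested in a functional assay on LM7 cells (Homo sapiens) for antiproliferative activity, read by MTT assay, with a stated time of 72 h; on this read-out higher numbers stand for weaker inhibition and lower numbers for stronger inhibition. Compound 2 `O=c1c(Cl)c(CSC(=S)N2CCOCC2)oc2ccccc12` gives 19200 nM in this assay. Compound 1 `CC(C)N(C(=S)SCc1oc2ccccc2c(=O)c1Cl)C(C)C` shares the core of compound 2; in this assay compound 1 returns > 40000 nM, which is a limit of the measurement and not a number. The change from compound 2 to compound 1 is diisopropylamino in place of morpholin-4-yl on a thiocarbonyl carbon, and it brought an at least 2.0-fold higher number from compound 2 to compound 1 (0.31 log units; beyond the scatter), a step whose size rests on (the limit of > 40000 nM in this assay, at which 1 of the 3 values shown sits).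

Compound 3 `O=c1c(CSC(=S)N2CCOCC2)coc2ccccc12` is built on a different core; the difference between the two cores is not broken down here. In this assay compound 3 gives 12000 nM, and the value of compound 2 lies within the scatter of that number, so the two cannot be told apart on this read-out.

Compound 4 `CC(C)N(C(=S)SCc1coc2ccccc2c1=O)C(C)C` has not yet been measured in this assay. Relative to compound 3 it carries diisopropylamino in place of morpholin-4-yl on a thiocarbonyl carbon, the same change as the one from compound 2 to compound 1, and occurring at the same place. Because the measured version of this change gave an at least 2.0-fold higher number from compound 2 to compound 1 (0.31 log units; beyond the scatter), the step expected in this assay is a 2.9-fold higher number from compound 3 to compound 4 (0.46 log units; beyond the scatter). Compound 4 is therefore estimated at 35000 nM in this assay, with a range from 18000 nM to 80000 nM, and with a real chance that the measurement reports only a limit.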

Compound 4, half-maximal inhibitory concentration: 21900 nM
Beside the measured number, compound 4's estimate is 1.6-fold (0.20 log units) above it; measured number inside the range.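

In this assay, the swap of morpholin-4-yl for diisopropylamino on the second core gave a 1.8-fold higher number from compound 3 to compound 4 (0.26 log units; within the scatter), so the step that lay beyond the scatter on the first core was not repeated as such on the second. This does not show that the change behaves differently on the two cores, and the comparison of the two steps stays unresolved: the same change on two cores in this assay, an at least 2.0-fold higher number (0.31 log units; beyond the scatter) from compound 2 to compound 1 and a 1.8-fold higher number (0.26 log units; within the scatter) from compound 3 to compound 4; the limit leaves it open whether they differ. Within the data shown here, the value of compound 1 is a limit of the assay and not a number, so the earlier step has no exact size to carry over, and this limit is the only one among the values shown: the limit of > 40000 nM in this assay, at which 1 of the 4 values shown sits.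

The compounds shown place only morpholin-4-yl and diisopropylamino on the thiocarbonyl carbon, so two amines on two cores are all that can be set side by side, and no trend across amines can be drawn from them. On these data alone, it remains open how a small open-chain amine such as dimethylamino, or a ring amine such as piperidine or piperazine, would read in this assay on either core, and whether a plain carbonyl in place of the thiocarbonyl would alter the picture.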